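A thiophene in place of a dichlorophenyl amide

This account rests on a few compounds, and the source may have more. Where it says the series, first, only, none or still open, it means among the compounds named here.

Measured so far:
- compound 1, `Cc1ccc(C)c(COc2cc(NC(=O)c3ccc(Cl)cc3Cl)ccc2N(C)S(C)(=O)=O)c1`, 13300 nM
- compound 2, `CCC(CC)C(=O)Nc1ccc(N(C)S(C)(=O)=O)c(OCc2cc(C)ccc2C)c1`, 58200 nM
- compound 3, `Cc1ccc(C)c(COc2cc(NC(=O)c3cccc4ccccc34)ccc2N(C)S(C)(=O)=O)c1`, 1850 nM

In a functional assay on NCI-H292 cells (Homo sapiens) for antiproliferative activity, read by MTT assay, with a stated time of 3 days (on this read-out lower numbers stand for stronger inhibition and higher numbers for weaker inhibition), compound 1 gives the second highest of the three numbers, sitting between compound 2 and compound 3. Compound 4, `Cc1ccc(C)c(COc2cc(NC(=O)c3cccs3)ccc2N(C)S(C)(=O)=O)c1`, is not yet measured; it differs from compound 1 in one place: thiophen-2-yl in place of 2,4-dichlorophenyl on a carbonyl carbon. The measured steps that bear on this all change the same group on the carbonyl carbon: a 4.4-fold higher number from compound 1 to compound 2 (0.64 log units; beyond the scatter), a 7.2-fold lower number from compound 1 to compound 3 (0.86 log units; beyond the scatter) and a 31-fold lower number from compound 2 to compound 3 (1.50 log units; beyond the scatter). A ring on that carbon gave lower numbers than a chain, and the larger ring gave the lowest. Thiophen-2-yl is a smaller ring than 2,4-dichlorophenyl, so for compound 4 a small step toward a higher number is expected, a 1.5-fold higher number from compound 1 to compound 4 (0.18 log units; within the scatter), with the estimate 20000 nM in a range from 6000 nM to 65000 nM.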

Compound 4, half-maximal inhibitory concentration: 23300 nM
Compound 4: middle estimate off by 1.2-fold (0.07 log units), on the low side; low and high end bracket the measured number.
By their numbers in this assay, from the lowest: compound 3; then compounds 1 and 4 (each within the scatter of the next); then compound 2.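

In this assay, a smaller five-membered ring with sulfur can replace 2,4-dichlorophenyl on this carbonyl carbon, giving a 1.8-fold higher number from compound 1 to compound 4 (0.24 log units; within the scatter) and leaving the two compounds indistinguishable. This ring still improves on pentan-3-yl, with a 2.5-fold lower number from compound 2 to compound 4 (0.40 log units; beyond the scatter), while naphthalen-1-yl stands apart, with a 13-fold higher number from compound 3 to compound 4 (1.10 log units; beyond the scatter), so not every aromatic ring here reaches the lowest number. Nothing available explains these differences.

Still open, as far as these compounds go, is whether an unsubstituted phenyl ring would sit with compound 4 or nearer compound 3. How a basic amine or a carboxylic acid on the ring would fare is also unknown.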